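Five-membered ring swaps on the shared core

The source may report more compounds than this note shows. Statements on the series, on what has been measured and on what is new or still open speak of the compounds shown alone.

Measured so far:
- compound 1 `c1c[nH]c(-c2ccccc2OCC2=NCCN2)c1`: 1.26 nM
- compound 2 `c1ccc(-c2ncc[nH]2)c(OCC2=NCCN2)c1`: 100 nM

In a functional assay for activation of Alpha-1A adrenergic receptor (Homo sapiens), read by calcium flux (on this read-out lower numbers stand for an effect already at smaller amounts and higher numbers for an effect only at larger amounts of compound), compound 2 gives 100 nM, the highest of the two numbers; its nearest neighbour is compound 1, whose number is lower by a 79-fold higher number from compound 1 to compound 2 (1.90 log units; beyond the scatter) read in reverse, a gap beyond the scatter. Compound 3 `Cc1ccc(-c2ccccc2OCC2=NCCN2)s1` has not been measured in this assay. It differs from compound 2 by 5-methylthiophen-2-yl in place of 1H-imidazol-2-yl on an aromatic carbon. For the measured compounds named here, the only measured step that bears on this change is the one from compound 1 to compound 2, a 79-fold higher number from compound 1 to compound 2 (1.90 log units; beyond the scatter), where a change of the same five-membered ring at the same place moved the number sharply. That step shows the ring at this place matters; it does not show which way a 5-methylthiophen-2-yl will go. Going by the values given here, a step of moderate size towards lower numbers is expected, a 13-fold lower number from compound 2 to compound 3 (1.10 log units; beyond the scatter), since the 1H-imidazol-2-yl of compound 2 carries the highest number so far and compound 1 with a one-heteroatom ring sits far lower. Compound 3 is therefore estimated at 8 nM, within 1 nM to 80 nM.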

Compound 3, half-maximal effective concentration: 25.1 nM
The estimate for compound 3 lay 3.1-fold (0.50 log units) below the measured number, within the range that was stated.
By their numbers in this assay, from the lowest: compound 1; then compound 3; then compound 2.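

In this assay, a five-membered ring without nitrogen is now seen at this place on the aromatic carbon: the 5-methylthiophen-2-yl of compound 3 brings the number down from the level of the 1H-imidazol-2-yl (a 4.0-fold lower number from compound 2 to compound 3 (0.60 log units; beyond the scatter)) but does not reach the level of the 1H-pyrrol-2-yl (a 20-fold higher number from compound 1 to compound 3 (1.30 log units; beyond the scatter)). With 0 hydrogen-bond donors in the entering group against 1 in the leaving group, the number still falls, so losing that donor does not by itself raise the number in this pair, and the ring at this place gives three clearly separated levels rather than a simple split between two outcomes. No measurement shown here accounts for this order of the three rings.

On these data alone, the step from compound 2 to compound 3 brings in the ring sulfur and the methyl together, so the share of each remains unknown, and a plain thiophen-2-yl would be the compound to separate them. Also open, as far as these compounds go, is whether a longer chain such as ethyl, or an amine or a carboxylic acid, in place of that methyl would move the number towards that of compound 1 or away from it.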